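The source may hold more compounds than are shown below. What is called first, only, known or untested is meant among the compounds shown, and "the series" means these compounds.

Compound 1: `O=S(=O)(c1cccc(Nc2ccc3nccc(-c4ccncc4)c3n2)c1)N1CCCC1` – < 5000 nM
Compound 2: `O=S(=O)(NCC1COC1)c1cccc(-c2ccc3nccc(-c4ccncc4)c3n2)c1` – 20000 nM

Of the compounds shown here, two have been measured in a physicochemical assay for solubility, read by HPLC, using the shake flask method, measured as kinetic solubility, with a stated time of 20 h, at pH 6.5, tested at 200 uM; on this read-out higher numbers stand for higher solubility and lower numbers for lower solubility. For compound 1 the result is a limit of the assay and not a number: in this assay compound 1 gives < 5000 nM. Among the measured compounds shown here, compound 2 is therefore the only one of the pair that carries a number; in this assay compound 2 gives 20000 nM, while the other value shown is the limit of < 5000 nM in this assay, at which 1 of the 2 values shown sits. For the measured compounds named here, compound 1 and compound 2 differ in more than one place, so no single step between them is counted, and only their two values can be set side by side.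

Compound 3, `C[C@@H](CO)NS(=O)(=O)c1cccc(-c2ccc3nccc(-c4ccncc4)c3n2)c1`, has yet to be measured in this assay. It differs from compound 2 in one place only: 1-(hydroxymethyl)ethyl in place of (oxetan-3-yl)methyl on a sulfonamide nitrogen. The change sits on the sulfonamide nitrogen, where 1-(hydroxymethyl)ethyl takes the place of (oxetan-3-yl)methyl, and it leaves the rest of the molecule as it stands in compound 2.

Going by the values given here, with no measured step of this kind to lean on, the change is expected to amount to a 1.3-fold higher number from compound 2 to compound 3 (0.10 log units; within the scatter), a step that stays within the usual scatter of repeated measurements. On that basis compound 3 is estimated at 25000 nM, with a range from 8000 nM to 80000 nM.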

Compound 3, solubility: 50000 nM
For compound 3 the middle estimate is 2.0-fold (0.30 log units) below the measured one; low and high end bracket the measured number.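

In this assay, the sulfonamide nitrogen now has its first measured step: 1-(hydroxymethyl)ethyl in place of (oxetan-3-yl)methyl gives a 2.5-fold higher number from compound 2 to compound 3 (0.40 log units; beyond the scatter), a modest step but one that lies beyond the usual scatter. This shows that the read-out at this position can respond to a change in the group on that nitrogen, although several things change together: the four-membered non-aromatic ring leaves, no ring enters, a hydrogen-bond donor comes in and a defined stereocentre appears, and a single step cannot separate them. The result for compound 1 remains a limit and not a number, and it has no part in this step: the limit of < 5000 nM in this assay, at which 1 of the 3 values shown sits.

Still open, going by these compounds, is which of those differences carries the step, and whether the other form of the stereocentre in 1-(hydroxymethyl)ethyl would read the same. On these data alone, it is also open how a longer chain with a terminal hydroxyl, an amine or a carboxylic acid on the sulfonamide nitrogen would read in this assay.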